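The source may report more compounds than this note shows. Statements on the series, on what has been measured and on what is new or still open speak of the compounds shown alone.

Measured so far:
- compound 1 `CC(C)(C)N(CCCc1ccccc1)C(=O)COC(=O)c1ccc([N+](=O)[O-])o1`: "not active" (no number reported)
- compound 2 `CC(=O)Oc1ccc(CN(C(=O)COC(=O)c2ccc([N+](=O)[O-])o2)C(C)(C)C)cc1`: > 100000 nM

Both compounds were tested in an ADME assay on HEK-293T cells (Homo sapiens) for cytotoxicity, read by MTT assay, with a stated time of 3 days; on this read-out higher numbers stand for lower toxicity in this test and lower numbers for higher toxicity in this test. Compound 1 is reported as "not active" (no number reported), with no number given. Compound 2 stands at > 100000 nM, which is a limit of the assay and not a number. This places compound 2 at the limit of > 100000 nM in this assay, at which 1 of the 2 values shown sits, so its true position on the scale is not known.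

The next compound is compound 3 `CC(C)(C)N(Cc1ccc(F)cc1)C(=O)COC(=O)c1ccc([N+](=O)[O-])o1`. It has fluoro in place of acetoxy on an aromatic carbon, para to a large group, so the 4-acetoxyphenyl of compound 2 becomes 4-fluorophenyl: fluoro in place of acetoxy on an aromatic carbon. Among the measured compounds shown here, the series offers no measured step between two compounds, so the size of this change in this assay cannot be read from earlier pairs. The expectation rests on compound 2 alone, whose > 100000 nM is a limit. No shift beyond the scatter is expected, and the expected step is a number no higher from compound 2 to compound 3 (the limit leaves the size open). A report of compound 3 as a limit again would fit this expectation. If a number is obtained, the estimate for compound 3 is 100000 nM. The expected range for compound 3 runs from 40000 nM to 200000 nM.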

Compound 3, half-maximal cytotoxic concentration: > 100000 nM
Compound 3: a limit, no number; the forecaster's own chance of this, stated with the estimate: 70%; the middle value sits exactly at the limit.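

In this assay compound 3 gives > 100000 nM, a limit of the assay and not a number. With compound 2 also at a limit, fluoro in place of acetoxy gives no readable step between compound 2 and compound 3. The compounds shown leave open where compound 2 and compound 3 truly lie on the scale, and whether this change shifts the read-out at all.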